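Series notes: the step from compound 2 to compound 4

This account rests on a few compounds, and the source may have more. Where it says the series, first, only, none or still open, it means among the compounds named here.

Measured so far in an assay on isolated protein for inhibition of vitamin D3 receptor (Homo sapiens), read by fluorescence polarization; a lower number here means a stronger inhibitor, a higher number a weaker inhibitor:
compound 1 `CS(=O)(=O)c1ccc(C(=O)NCC(=O)N(Cc2ccccc2)Cc2ccccc2)cc1[N+](=O)[O-]` gives > 60000 nM, a limit of the assay.
compound 2 `Cc1ccc(N2CCN(C(=O)C3CCN(C(=O)c4ccc(S(C)(=O)=O)c([N+](=O)[O-])c4)CC3)CC2)cc1` gives > 60000 nM, a limit of the assay.
compound 3 `CN1CCN(C(=O)CNC(=O)c2ccc(S(C)(=O)=O)c([N+](=O)[O-])c2)CC1` gives > 60000 nM, a limit of the assay.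

Compound 2 therefore stands only at a limit in this assay, and the same holds for the two other measured compounds; no value is a number, so nothing orders compound 1, compound 2 and compound 3 against one another: the limit of > 60000 nM in this assay, at which 3 of the 3 values shown sit. Among the measured compounds shown here, no step between measured compounds that differ in one place is available, so the size of any structural change has not yet been read on the numbers.

The unmeasured compound 4 `CN1CCN(C(=O)C2CCN(C(=O)c3ccc(S(C)(=O)=O)c([N+](=O)[O-])c3)CC2)CC1` differs from compound 2 in one place: methyl in place of 4-methylphenyl on an amine nitrogen in a ring. Compound 3 also carries a methyl on an amine nitrogen in a ring and sits at the limit, which gives no hint of a gain.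

For compound 4 no step beyond the scatter is expected in this assay, in either direction, and a limit is the most likely outcome. The expected step is a step that the limit leaves unreadable from compound 2 to compound 4, within the scatter. Compound 4 is estimated at 100000 nM, with a range from 30000 nM to 300000 nM.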

Compound 4, half-maximal inhibitory concentration: > 60000 nM
Compound 4 ended at the assay's limit; the forecaster's own chance of this, stated with the estimate: 85%; the middle value lies beyond the limit too.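

In this assay compound 4 gives > 60000 nM, a limit of the assay. Compound 2 also stands at a limit, so no step can be read for methyl in place of 4-methylphenyl between compound 2 and compound 4. Still open is which structural change, if any, would give a readable number in this assay: the limit of > 60000 nM in this assay, at which 4 of the 4 values shown sit.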